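Methoxy added to the aryl ring: cytotoxicity notes

The compounds below may be only part of what the source reports. "The series", "measured", "known", "first", "only" and "open" are said of these compounds alone.

In an ADME assay on MDCK cells (Canis lupus familiaris) for cytotoxicity, read by MTT assay, with a stated time of 48 h (a higher number here means that more compound is tolerated, a lower number that less compound is tolerated), compound 1 `COc1ccc([C@H]2CC(C)(O)[C@@H]3CC[C@@H](C)C[C@H]3O2)cc1OC` gives only a limit, > 937000 nM. Compound 2 `COc1ccc([C@H]2CC(C)(O)[C@@H]3CC[C@@H](C)C[C@H]3O2)c(OC)c1OC` likewise gives a limit in this assay, > 857000 nM. The change between them, (methoxy in place of hydrogen on an aromatic carbon), produces a step that the two limits leave unreadable from compound 1 to compound 2 because the limit of > 857000 nM in this assay, at which 1 of the 3 values shown sits, and the limit of > 937000 nM in this assay, at which 1 of the 3 values shown sits, leave no number to compare. Compound 3 `COc1cc([C@H]2CC(C)(F)[C@@H]3CC[C@@H](C)C[C@H]3O2)ccc1O` rests on another core; how that core differs from the core of compound 1 is not broken down here. In this assay, going by the values given here, compound 3 gives 642000 nM, the only number among the three. Compound 4 `COc1cc([C@H]2CC(C)(F)[C@@H]3CC[C@@H](C)C[C@H]3O2)cc(OC)c1O` arises from compound 3 by methoxy in place of hydrogen on an aromatic carbon, the same kind of change as from compound 1 to compound 2, but at a different place: ortho to a hydroxy group, meta to a large group and meta to a methoxy group, rather than ortho to a large group, ortho to a methoxy group and meta to a methoxy group. With the earlier step unreadable, the step expected from compound 3 to compound 4 is a 1.1-fold higher number from compound 3 to compound 4 (0.04 log units; within the scatter), kept small. Compound 4 is therefore estimated at 700000 nM, with a range from 350000 nM to 1400000 nM.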

Compound 4, half-maximal cytotoxic concentration: 158000 nM
The estimate for compound 4 lay 4.4-fold (0.65 log units) above the measured number; the whole stated range lies above it.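

In this assay, methoxy in place of hydrogen on an aromatic carbon gives a 4.1-fold lower number from compound 3 to compound 4 (0.61 log units; beyond the scatter), with the new group ortho to a hydroxy group, meta to a large group and meta to a methoxy group. Compound 1 gives only a limit: the limit of > 937000 nM in this assay, at which 1 of the 4 values shown sits. Compound 2 also gives only a limit, so the same change on that core cannot be read, and nothing shows whether the step carries from one core to the other: the limit of > 857000 nM in this assay, at which 1 of the 4 values shown sits.

The two changes also sit at different places, so the effect of place and the effect of core remain unseparated. From the compounds shown here alone, whether an amine or a longer chain in place of that hydrogen would give a step of similar size remains open.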